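Halogen swap on a sulfonamide benzanilide: cytotoxicity outlook

The source may report more compounds than this note shows. Statements on the series, on what has been measured and on what is new or still open speak of the compounds shown alone.

compound 1 `COc1cc(NC(=O)c2ccc(C#N)cc2)ccc1NS(C)(=O)=O` — > 250000 nM
compound 2 `CS(=O)(=O)Nc1ccc(NC(=O)c2ccc(C#N)cc2)cc1Cl` — > 250000 nM

In an ADME assay on RAW264.7 cells (Mus musculus) for cytotoxicity, read by MTT assay, with a stated time of 48 h (a higher number here means a weaker inhibitor, a lower number a stronger inhibitor), compound 1 gives > 250000 nM, which is a limit of the assay rather than a number. In this assay compound 2 gives > 250000 nM, also a limit. Compound 2 thus stands at the limit of > 250000 nM in this assay, at which 2 of the 2 values shown sit. Within the data shown here, the single measured step, a step that the two limits leave unreadable from compound 1 to compound 2, is unreadable in size. Compound 3 `CS(=O)(=O)Nc1ccc(NC(=O)c2ccc(C#N)cc2)cc1F` differs from compound 2 by fluoro in place of chloro on an aromatic carbon. Among the measured compounds shown here, no measured step resolves this change; what is known is that compound 2 sits at the limit of > 250000 nM in this assay, at which 2 of the 2 values shown sit. Compound 3 is therefore expected to remain at that limit, with an estimated 400000 nM (range 250000 nM to 1000000 nM), an expected step that the limit leaves unreadable from compound 2 to compound 3.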

Compound 3, half-maximal inhibitory concentration: > 250000 nM
Compound 3 gave a limit, no number; the forecaster's own chance of this, stated with the estimate: 90%; the middle value is on the limit's open side.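

No new step can be read, because compound 3 joins compound 1 and compound 2 at a limit, not a number: the limit of > 250000 nM in this assay, at which 3 of the 3 values shown sit.

The compounds shown leave open whether methoxy, chloro or fluoro at this place makes any difference in this assay.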